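This account rests on a few compounds, and the source may have more. Where it says the series, first, only, none or still open, it means among the compounds named here.

Compound 3 `CC(C)c1c(C(=O)N2CCCC2c2ccccc2)nn(-c2ccc(F)cc2)c1OC[C@@H](O)C[C@@H](O)CC(=O)O` gives 14 nM in an assay on microsomes from liver for inhibition of 3-hydroxy-3-methylglutaryl-coenzyme A reductase (Rattus norvegicus) (on this read-out higher numbers stand for weaker inhibition and lower numbers for stronger inhibition), the highest of the three numbers measured. Compound 1 `CC(C)c1c(C(=O)NCc2ccccc2)nn(-c2ccc(F)cc2)c1OC[C@@H](O)C[C@@H](O)CC(=O)O` gives 3.8 nM and compound 2 `CC(C)c1c(C(=O)N(C)Cc2ccccc2)nn(-c2ccc(F)cc2)c1OC[C@@H](O)C[C@@H](O)CC(=O)O` gives 5.2 nM. The change to compound 4 `Cc1ccc(CNC(=O)c2nn(-c3ccc(F)cc3)c(OC[C@@H](O)C[C@@H](O)CC(=O)O)c2C(C)C)cc1` is (4-methylbenzyl)amino in place of 2-phenylpyrrolidin-1-yl on a carbonyl carbon. For the measured compounds named here, the steps that bear on it run the other way: a 3.7-fold higher number from compound 1 to compound 3 (0.57 log units; beyond the scatter) and a 2.7-fold higher number from compound 2 to compound 3 (0.43 log units; beyond the scatter), each a modest rise. Reversing that change, with a methyl added on the benzyl ring, compound 4 is therefore expected to show a modest fall in this assay, by about a 3.1-fold lower number from compound 3 to compound 4 (0.49 log units; beyond the scatter). Compound 4 is estimated at 4.5 nM, with a range of 1.8 nM to 11 nM.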

Compound 4, half-maximal inhibitory concentration: 15 nM
The estimate for compound 4 lay 3.3-fold (0.52 log units) below the measured number, outside the stated range (above it).
By their numbers in this assay, from the lowest: compounds 1 and 2 (each within the scatter of the next); then compounds 3 and 4 (each within the scatter of the next).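

Methyl in place of hydrogen on an aromatic carbon of the benzyl group is not neutral in this assay: the result is a 3.9-fold higher number from compound 1 to compound 4 (0.60 log units; beyond the scatter). Against the tertiary amide, the change to (4-methylbenzyl)amino gives a 2.9-fold higher number from compound 2 to compound 4 (0.46 log units; beyond the scatter), so keeping the amide hydrogen does not by itself preserve the low number. Replacing 2-phenylpyrrolidin-1-yl with (4-methylbenzyl)amino gives a 1.1-fold higher number from compound 3 to compound 4 (0.03 log units; within the scatter), so these two groups cannot be told apart here. Nothing available explains the effect of the methyl. On these data alone, whether fluorine or methoxy in place of that methyl would give the same rise remains open.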